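Putting Isopropyl Back on the Amide-Type Nitrogen

The compounds below may be only part of what the source reports. "The series", "measured", "known", "first", "only" and "open" are said of these compounds alone.

Compound 1 `CC(C)NC(=O)N1CCN(C(=S)SCc2cn(Cc3ccccc3F)nn2)CC1`: in a functional assay on MGC-803 cells (Homo sapiens) for cytotoxicity, read by MTT assay, with a stated time of 72 h (a higher number here means a weaker inhibitor, a lower number a stronger inhibitor), compound 1 gives 1620 nM.
Compound 2 `NC(=O)N1CCN(C(=S)SCc2cn(Cc3ccc(Cl)cc3)nn2)CC1`: in this assay compound 2 reaches only the limit of the assay, > 128000 nM, which is not a measured number.

Compound 2 therefore stands at the ceiling of what the measurement can report, as described by the limit of > 128000 nM in this assay, at which 1 of the 2 values shown sits. Among the measured compounds shown here, compound 1 differs from compound 2 in two places at once, so no single step joins them; the two values show only that compound 1 has a measured number where compound 2 has none.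

Compound 3 `CC(C)NC(=O)N1CCN(C(=S)SCc2cn(Cc3ccc(Cl)cc3)nn2)CC1` differs from compound 2 by a single change: isopropyl in place of hydrogen on an amide-type nitrogen. Compound 3 is expected to be a far stronger inhibitor than compound 2, because compound 1, which carries the same isopropylcarbamoyl group, gives 1620 nM in this assay. That expectation amounts to a step of an at least 42-fold lower number from compound 2 to compound 3 (1.63 log units; beyond the scatter), well beyond the usual scatter. Compound 3 is accordingly estimated at 3000 nM, within a range from 700 nM to 30000 nM.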

Compound 3, half-maximal inhibitory concentration: 19900 nM
Beside the measured number, compound 3's estimate is 6.6-fold (0.82 log units) below it, and the stated range covers the measured number.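

In this assay, isopropyl in place of hydrogen on the amide-type nitrogen gives an at least 6.4-fold lower number from compound 2 to compound 3 (0.80 log units; beyond the scatter), so this one change turns a compound stuck at a limit into one with a measured number. How large the step really is stays open because the value for compound 2 is a limit and not a number: the limit of > 128000 nM in this assay, at which 1 of the 3 values shown sits.

With the isopropylcarbamoyl group held fixed, the other end of the molecule also counts: 4-chlorophenyl in place of 2-fluorophenyl on a saturated chain carbon bound to an aromatic nitrogen gives a 12-fold higher number from compound 1 to compound 3 (1.09 log units; beyond the scatter).

The compounds shown leave open whether isopropyl itself matters or whether methyl, a longer chain such as butyl, or a cyclohexyl ring on that nitrogen would serve as well. They also leave open how a plain phenyl would read at the other end.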